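Side-chain heterocycle swap on the weaker aryl analogue

A few compounds are considered here, and "the series" means these few. Any claim that something is new, unique, unknown or untested is made for them only; others in the source may bear on it.

Measured so far in a functional assay (aorta) with Rattus norvegicus as the target; a higher number here means a weaker inhibitor, a lower number a stronger inhibitor:
compound 1 `CCO/C(O)=C1\C(COCCn2cc(C(N)=O)nn2)=NC(C)=C(C(=O)OC)C1c1cccc(Cl)c1Cl` gives 3.16 nM
compound 2 `CCO/C(O)=C1\C(COCCn2cc(C(N)=O)nn2)=NC(C)=C(C(=O)OC)C1c1ccccc1Cl` gives 20 nM
compound 3 `CCO/C(O)=C1\C(COCCN2CC(=O)N(C)C2=O)=NC(C)=C(C(=O)OC)C1c1cccc(Cl)c1Cl` gives 5.01 nM

Compound 2 has the highest number of the three in this assay, separated from compound 3 and from compound 1 by steps beyond the scatter; it reaches compound 1 through a 6.3-fold higher number from compound 1 to compound 2 (0.80 log units; beyond the scatter). Compound 4 `CCO/C(O)=C1\C(COCCn2cnc3ccccc32)=NC(C)=C(C(=O)OC)C1c1ccccc1Cl` differs from compound 2 only in the side chain: 1H-benzimidazol-1-yl in place of 4-carbamoyl-1H-1,2,3-triazol-1-yl on a saturated chain carbon, two bonds along the chain from an oxygen on a saturated carbon. Among the compounds with values here, the one measured step that bears on this kind of change is the heterocycle exchange on the same chain position, a 1.6-fold higher number from compound 1 to compound 3 (0.20 log units; within the scatter), which stayed within the scatter. Within the data shown here, no measured pair shows a benzimidazole at that position, so its effect beyond what the triazole-to-imidazolidinedione swap suggests is unknown. On that basis the expected step of a 1.3-fold higher number from compound 2 to compound 4 (0.10 log units; within the scatter) is small, with the direction uncertain, and a wide range is kept for the untested group. Compound 4 is estimated at 25 nM, between 8 nM and 80 nM.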

Compound 4, half-maximal inhibitory concentration: 20 nM
Estimate against measurement, compound 4: 1.3-fold (0.10 log units) above; the range from low to high includes it.
By their numbers in this assay, from the lowest: compounds 1 and 3 (each within the scatter of the next); then compounds 2 and 4 (each within the scatter of the next).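

In this assay, no change at the digits printed from compound 2 to compound 4 (within the scatter) shows that this saturated chain carbon, two bonds along the chain from an oxygen on a saturated carbon, takes 1H-benzimidazol-1-yl in place of 4-carbamoyl-1H-1,2,3-triazol-1-yl without a step beyond the scatter. The change also takes the side chain from 1 hydrogen-bond donor to 0 and from 4 hydrogen-bond acceptors to 2, and adds a six-membered aromatic ring of carbon only, yet the number stays put. Together with a 1.6-fold higher number from compound 1 to compound 3 (0.20 log units; within the scatter), a side-chain heterocycle exchange now stays within the scatter on both aryl groups shown, and neither pair goes against this.

Going by these compounds, whether 1H-benzimidazol-1-yl behaves the same on the aryl group of compound 1, and whether a carboxylic acid or a piperidine on this chain would fit the same pattern, remains open. Nothing available explains the flat result.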